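The compounds below may be only part of what the source reports. "The series", "measured", "known", "first", "only" and "open" are said of these compounds alone.

Measured so far:
- compound 1 `O=C(NCCCNc1cc(-c2cn(-c3ccccc3)nc2-c2cccc(O)c2)ccn1)Nc1ccc(F)cc1`: 4990 nM
- compound 2 `O=C(NCCCNc1cc(-c2cn(-c3ccccc3)nc2-c2cccc(O)c2)ccn1)Nc1cccc(C(F)(F)F)c1`: 6190 nM

In a functional assay on HT-29 cells (Homo sapiens) for antiproliferative activity, read by sulforhodamine B assay, with a stated time of 48 h (a higher number here means a weaker inhibitor of growth, a lower number a stronger inhibitor of growth), compound 1 gives 4990 nM and compound 2 gives 6190 nM. These two values lie within the usual scatter of repeated measurements, so compound 1 cannot be ranked apart from compound 2.

The next compound to be tested is compound 3 `COc1cccc(-c2nn(-c3ccccc3)cc2-c2ccnc(NCCCNC(=O)Nc3ccc(F)cc3)c2)c1`. It differs from compound 1 at one place: methyl in place of hydrogen on an oxygen on an aromatic ring. Put simply, methyl takes the place of hydrogen on an oxygen on an aromatic ring, turning 3-hydroxyphenyl into 3-methoxyphenyl.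

Among the measured compounds shown here, only one measured step is available for comparison: a 1.2-fold higher number from compound 1 to compound 2 (0.09 log units; within the scatter). That step exchanges 4-fluorophenyl for 3-(trifluoromethyl)phenyl on an amide-type nitrogen and leaves the 3-hydroxyphenyl group untouched. It shows that one change elsewhere in the structure did not move the value beyond the scatter, but it does not test the hydroxy to methoxy change. The data therefore give no direction for the new change, so a wide range is appropriate.

The expected change is a 1.2-fold higher number from compound 1 to compound 3 (0.08 log units; within the scatter), which means no clear shift is anticipated. For compound 3, the estimated value is 6000 nM, with an expected range of 2500 nM to 14000 nM.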

Compound 3, concentration for total growth inhibition: 18200 nM
For compound 3 the middle estimate is 3.0-fold (0.48 log units) below the measured one; the whole stated range lies below it.
By their numbers in this assay, from the lowest: compounds 1 and 2 (each within the scatter of the next); then compound 3.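

In this assay, the hydroxy to methoxy change gives a 3.6-fold higher number from compound 1 to compound 3 (0.56 log units; beyond the scatter), beyond the scatter, so compound 3 is a weaker inhibitor of growth than compound 1. Among the compounds shown here, this is the first sign that the value can respond to a structural change: the earlier swap on the amide-type nitrogen gave only a 1.2-fold higher number from compound 1 to compound 2 (0.09 log units; within the scatter), within the scatter, while here a methyl on the oxygen of the 3-hydroxyphenyl group is enough to produce a modest but readable loss. Nothing measured here explains why this small change weakens growth inhibition.

The compounds shown cannot separate the loss of the hydrogen on that oxygen from the arrival of the methyl, and they do not reveal whether other groups at this place, such as an amine, a fluorine or the longer ethoxy, would stay close to compound 1 or fall further away. For the compounds shown here, it also remains open whether the same methyl would cost as much when the 3-(trifluoromethyl)phenyl group of compound 2 is present, since this change has been read in only one pair.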